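Cyclohexylmethyl in Place of the Carboxyethylcarbonyl Chain

The source may report more compounds than this note shows. Statements on the series, on what has been measured and on what is new or still open speak of the compounds shown alone.

Compound 1, `Cn1nccc1C(=O)Nc1ccc2nc(NC(=O)C3CCCCC3)sc2c1`: 0.58 ug/mL
Compound 2, `Cc1[nH][n+](C)c(C)c1C(=O)Nc1ccc2nc(NC(=O)C3CCCCC3)sc2c1`: 0.012 ug/mL
Compound 3, `O=C(O)CCC(=O)Nc1nc2ccc(NC(=O)c3c(Cl)cccc3Cl)cc2s1`: a limit, > 6.6 ug/mL

In a functional assay on WI-38 VA13 cells (Homo sapiens) for cytotoxicity (on this read-out higher numbers stand for an effect only at larger amounts of compound and lower numbers for an effect already at smaller amounts), compound 3 gives only a limit, > 6.6 ug/mL, and so no number of its own; of the three measured compounds it alone sits at the limit of > 6.6 ug/mL in this assay, at which 1 of the 3 values shown sits. The two compounds with a number, compound 1 and compound 2, differ from each other by a 48-fold lower number from compound 1 to compound 2 (1.68 log units; beyond the scatter), a change on a carbonyl carbon that touches neither the nitrogen on the aromatic ring nor the group carried there, so it does not bear on the step considered here.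

Compound 4, `O=C(Nc1ccc2nc(NCC3CCCCC3)sc2c1)c1c(Cl)cccc1Cl`, has not yet been measured. It differs from compound 3 by cyclohexylmethyl in place of (2-carboxyethyl)carbonyl on a nitrogen on an aromatic ring. Among the measured compounds shown here, no measured step follows this change, and compound 3 itself gives only a limit, so the expected step can only be bounded loosely. Since compound 1 and compound 2, which both carry a cyclohexyl ring on the amide at that nitrogen, give numbers well inside the range of this assay, compound 4 is estimated to yield a number rather than a limit, with the step of an at least 4.4-fold lower number from compound 3 to compound 4 (0.64 log units; beyond the scatter) expected in the direction of a lower number. Compound 4 is expected to give about 1.5 ug/mL, in a range from 0.15 ug/mL to 6.6 ug/mL.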

Compound 4, half-maximal effective concentration: 4.3 ug/mL
Estimate against measurement, compound 4: 2.9-fold (0.46 log units) below, within the range that was stated.
By their numbers in this assay, from the lowest: compound 2; then compound 1; then compound 4. At a limit, above all of these: compound 3.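

In this assay compound 4 gives 4.3 ug/mL with cyclohexylmethyl in place of (2-carboxyethyl)carbonyl on the nitrogen on the aromatic ring, so this change at this position yields a number where the earlier compound with the same amide group on the other side of the core gave none. The change can be read only as an at least 1.5-fold lower number from compound 3 to compound 4 (0.18 log units; that floor lies within the scatter) and no further, so the pair fixes a floor rather than a size, and that floor alone does not carry the step past the usual scatter. Compound 3 remains a limit and not a number, the only one among the compounds shown: the limit of > 6.6 ug/mL in this assay, at which 1 of the 4 values shown sits.

The pair changes two things at once, so it leaves open how much of the step goes with losing the carboxylic acid and how much with gaining the cyclohexane ring. Also open, from the compounds shown here alone, is what a simple acetyl group, a cyclohexylcarbonyl group or a longer chain ending in an amine would give on this nitrogen with the rest of compound 4 unchanged.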